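Changing one ring and watching how fast compounds cross a membrane

This account rests on a few compounds, and the source may have more. Where it says the series, first, only, none or still open, it means among the compounds named here.

Three compounds have been measured in an ADME assay for permeability, using PAMPA, with a stated time of 30 min, at pH 7.4; a higher number here means that the compound crosses the layer faster, a lower number that the compound crosses the layer more slowly:

Compound 1 `COc1ccc(F)cc1CNCCCNc1ccnc2cc(C3CCCCC3)ccc12` gives 23 10^-6 cm/s.
Compound 2 `COc1ccc(F)cc1CNCCCNc1ccnc2cc(-c3cccc4ccccc34)ccc12` gives 237 10^-6 cm/s.
Compound 3 `c1coc(CNCCCNc2ccnc3cc(-c4cccc5ccccc45)ccc23)c1` gives 237 10^-6 cm/s.

Compound 3 differs from compound 2 in the group on the amine side of the chain: furan-2-yl in place of 5-fluoro-2-methoxyphenyl on a saturated chain carbon bound to an amine nitrogen. That change left the read-out where it was, since no change at the digits printed from compound 2 to compound 3 (within the scatter). Compound 1 differs from compound 2 at the other end of the molecule, on the shared core: cyclohexyl in place of naphthalen-1-yl on an aromatic carbon. Here the read-out moved a long way, since a 10-fold lower number from compound 2 to compound 1 (1.01 log units; beyond the scatter).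

Compound 4 `c1coc(CNCCCNc2ccnc3cc(C4CCCCC4)ccc23)c1` has not yet been measured. It differs from compound 3 by cyclohexyl in place of naphthalen-1-yl on an aromatic carbon, which is the same change, at the same place, that separates compound 1 from compound 2. The expectation is that compound 4 will show a step of a 9.9-fold lower number from compound 3 to compound 4 (0.99 log units; beyond the scatter), because a 10-fold lower number from compound 2 to compound 1 (1.01 log units; beyond the scatter) and because no change at the digits printed from compound 2 to compound 3 (within the scatter) showed that the amine-side group did not shift the number. Compound 4 is therefore estimated at 24 10^-6 cm/s, expected to fall between 10 10^-6 cm/s and 60 10^-6 cm/s. The measurement will show whether the change repeats.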

Compound 4, apparent permeability: 23 10^-6 cm/s
Estimate against measurement, compound 4: 1.0-fold (0.02 log units) above, and the stated range covers the measured number.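

In this assay, cyclohexyl in place of naphthalen-1-yl gave a 10-fold lower number from compound 3 to compound 4 (1.01 log units; beyond the scatter), and this step matches the one seen earlier on the other core: the same change on two cores in this assay, a 10-fold lower number (1.01 log units; beyond the scatter) from compound 2 to compound 1 and a 10-fold lower number (1.01 log units; beyond the scatter) from compound 3 to compound 4, 1.0-fold (0.00 log units) apart, within the scatter of two such steps. The other change behaved just as consistently, with furan-2-yl in place of 5-fluoro-2-methoxyphenyl giving no change at the digits printed from compound 1 to compound 4 (within the scatter), the same result as with naphthalen-1-yl on the core: the same change on two cores in this assay, no change at the digits printed (within the scatter) from compound 2 to compound 3 and no change at the digits printed (within the scatter) from compound 1 to compound 4, 1.0-fold (0.00 log units) apart, within the scatter of two such steps. Among these four compounds, the two changes therefore act independently, so the step for one can be carried across the other, but two pairs per change do not show why this happens or that it will hold for other compounds in the series.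

As far as these compounds go, it remains open whether a phenyl ring in place of naphthalen-1-yl would give a number nearer the high or the low end, and whether a pyridine ring in place of furan-2-yl would leave the number unchanged. From the compounds shown here alone, a longer chain linking the two amine nitrogens is also untested here, so its effect on the read-out is unknown.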